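A few compounds are considered here, and "the series" means these few. Any claim that something is new, unique, unknown or untested is made for them only; others in the source may bear on it.

Compound 1 `O=C(Nc1ccc(I)cc1)N[C@H]1CC[C@H](Oc2ccc(F)cc2)CC1` is the starting point of this comparison. In a functional assay on CRL2813 cells (Homo sapiens) for cytotoxicity, read by sulforhodamine B assay, with a stated time of 5 days (a lower number here means a stronger inhibitor, a higher number a weaker inhibitor), compound 1 gives 10200 nM. Compound 3 `COc1cccc(NC(=O)N[C@H]2CC[C@H](Oc3ccc(F)cc3)CC2)c1` gives 14000 nM in this assay, and the gap between compound 1 and compound 3, a 1.4-fold higher number from compound 1 to compound 3 (0.14 log units; within the scatter), sits inside the scatter, so the two numbers cannot be told apart. Compound 2 `O=C(Nc1ccc(Br)cc1)N[C@H]1CC[C@H](Oc2ccc(F)cc2)CC1` reaches only a limit of the assay, > 20000 nM, which is the limit described by the limit of > 20000 nM in this assay, at which 1 of the 3 values shown sits. The step from compound 1 to compound 2, an at least 1.9-fold higher number from compound 1 to compound 2 (0.29 log units; that floor lies within the scatter), is therefore known only as a floor.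

Compound 4 `O=C(Nc1cccc(Br)c1)N[C@H]1CC[C@H](Oc2ccc(F)cc2)CC1` differs from compound 1 by 3-bromophenyl in place of 4-iodophenyl on an amide-type nitrogen. Among the measured compounds shown here, two measured steps bear on this change. The exchange of iodo for bromo on an aromatic carbon gave an at least 1.9-fold higher number from compound 1 to compound 2 (0.29 log units; that floor lies within the scatter), while the move to a 3-substituted phenyl on the amide-type nitrogen gave a 1.4-fold higher number from compound 1 to compound 3 (0.14 log units; within the scatter). Both point, weakly, toward a higher number, and one of them ended at a limit. Compound 4 is therefore expected to give a number no lower than that of compound 1, with the estimated step of a 1.8-fold higher number from compound 1 to compound 4 (0.25 log units; within the scatter). Compound 4 is estimated at 18000 nM, with a range from 8000 nM to 40000 nM, and a real chance that the assay again reports only a limit.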

Compound 4, half-maximal inhibitory concentration: 6200 nM
Estimate against measurement, compound 4: 2.9-fold (0.46 log units) above; the whole stated range lies above it.
By their numbers in this assay, from the lowest: compounds 4, 1 and 3 (each within the scatter of the next, the first and the last beyond it). At a limit, above all of these: compound 2.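

In this assay, the place of the bromo on the phenyl group first proves to count, with the halogen held the same: 3-bromophenyl in place of 4-bromophenyl on the amide-type nitrogen gives an at least 3.2-fold lower number from compound 2 to compound 4 (0.50 log units; beyond the scatter). That step is only a floor, set by compound 2, whose value is a limit and not a number: the limit of > 20000 nM in this assay, at which 1 of the 4 values shown sits. Among the phenyl groups substituted in the same place, the exchange of methoxy for bromo also registers, with a 2.3-fold lower number from compound 3 to compound 4 (0.35 log units; beyond the scatter), whereas 3-bromophenyl and 4-iodophenyl cannot be told apart, with a 1.6-fold lower number from compound 1 to compound 4 (0.22 log units; within the scatter) lying within the scatter.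

The compounds shown leave open the true size of the step between the two bromophenyl compounds, and whether the link between the place of the halogen and the number holds for iodo as it does for bromo. They also leave open how a chloro, an amine, a carboxylic acid or a longer chain would behave in place of the bromo of compound 4 on the shared core.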